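The source may hold more compounds than are shown below. What is called first, only, known or untested is meant among the compounds shown, and "the series" means these compounds.

Compound 1, `COC(=O)[C@@]1(C)CCC=C2[C@@H]1CC[C@@H](C)[C@]2(C)Cc1c(C)[nH]c2c(C)cccc12`, gives 21000 nM in a functional assay on WiDr cells (Homo sapiens) for inhibition, read by sulforhodamine B assay, with a stated time of 48 h; on this read-out lower numbers stand for stronger inhibition of growth and higher numbers for weaker inhibition of growth.
Compound 2, `COC(=O)[C@@]1(C)CCC=C2[C@@H]1CC[C@@H](C)[C@]2(C)Cc1c(C)[nH]c2c(Br)cccc12`, gives 38000 nM in this assay.

Within the data shown here, compound 2 stands at the higher of the two numbers measured so far, with compound 1 as its only neighbour, and the step of a 1.8-fold higher number from compound 1 to compound 2 (0.26 log units; within the scatter) is within the scatter. Compound 3, `COC(=O)[C@@]1(C)CCC=C2[C@@H]1CC[C@@H](C)[C@]2(C)Cc1c(C)[nH]c2c(Cl)cccc12`, differs from compound 2 by chloro in place of bromo on an aromatic carbon. Among the measured compounds shown here, the one measured step that bears on this change is a 1.8-fold higher number from compound 1 to compound 2 (0.26 log units; within the scatter), an exchange of the group on the same aromatic carbon, and it was small. On that basis no step beyond the scatter is expected in this assay, in either direction. Compound 3 is therefore expected to give about 30000 nM, with a range from 15000 nM to 60000 nM. The expected step of a 1.3-fold lower number from compound 2 to compound 3 (0.10 log units; within the scatter) would stay within the scatter.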

Compound 3, concentration for 50% growth inhibition: 29000 nM
Compound 3: the middle estimate sits 1.0-fold (0.01 log units) above what was measured; low and high end bracket the measured number.
By their numbers in this assay, from the lowest: compounds 1, 3 and 2 (each within the scatter of the next).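

With chloro, this aromatic carbon has now carried methyl, bromo and chloro, and in this assay both a 1.3-fold lower number from compound 2 to compound 3 (0.12 log units; within the scatter) and a 1.4-fold higher number from compound 1 to compound 3 (0.14 log units; within the scatter) stay within the scatter. The earlier compounds showed this only for one exchange, whereas the three compounds now show that no exchange among these groups separates them on this read-out, whether one halogen replaces the other or chloro replaces methyl. No evidence is at hand that would explain these numbers.

The compounds shown leave open whether a group of another kind on this carbon, such as an amine, a methoxy group or a carboxylic acid, would move the number beyond the scatter. They also leave open whether fluoro or a longer alkyl chain here would behave like the three groups seen so far.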